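Compound 1 to compound 3: bromo in place of methoxy

The compounds below may be only part of what the source reports. "The series", "measured", "known", "first", "only" and "open" are said of these compounds alone.

In an ADME assay on HepG2 cells (Homo sapiens) for cytotoxicity, read by trypan blue exclusion, with a stated time of 48 h, in the presence of a further agent that is not named here (on this read-out lower numbers stand for higher toxicity in this test and higher numbers for lower toxicity in this test), so far:
- compound 1 `COc1cccc(NC(=O)COc2cc(C)nc3ccc(OC)cc23)c1` gives 24700 nM as a number
- compound 2 `COc1cc(NC(=O)COc2cc(C)nc3ccc(OC)cc23)cc(OC)c1` gives > 131000 nM as a limit

Among the compounds with values here, compound 1 holds the only actual number in this short series. Compound 2 sits at the limit of > 131000 nM in this assay, at which 1 of the 2 values shown sits, and that is a limit, not a number.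

Compound 3 `COc1ccc2nc(C)cc(OCC(=O)Nc3cccc(Br)c3)c2c1` has bromo in place of methoxy on an aromatic carbon on a six-membered aromatic ring of carbon only, meta to a large group.

Within the data shown here, the one measured step is an at least 5.3-fold higher number from compound 1 to compound 2 (0.72 log units; beyond the scatter) with methoxy in place of hydrogen on an aromatic carbon. That step adds a methoxy rather than exchanging one, so it bears only loosely on this change. No step beyond the scatter is therefore expected in this assay in either direction.

The expected step is a 1.1-fold higher number from compound 1 to compound 3 (0.02 log units; within the scatter) by this estimate. Compound 3 is estimated at 26000 nM with an expected range from 8000 nM to 85000 nM for now.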

Compound 3, half-maximal cytotoxic concentration: > 125000 nM
Compound 3: a limit, no number; the forecaster's own chance of this, stated with the estimate: 12%; middle value at least 4.8-fold (0.68 log units) from the limit.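

In this assay compound 3 gives > 125000 nM as a limit of the assay and not a number. The change from 3-methoxyphenyl to 3-bromophenyl gives an at least 5.0-fold higher number from compound 1 to compound 3 (0.70 log units; beyond the scatter) so exchanging the methoxy at this place, and not only adding a second methoxy as in compound 2, moves the read-out beyond the scatter towards lower toxicity in this test. Compound 1 remains the only compound with an actual number, and compound 3 now also stands at a limit: the limit of > 125000 nM in this assay, at which 1 of the 3 values shown sits.

Any step between compound 2 and compound 3 cannot be read, and the full size of the rise from compound 1 stays open. Also open, from the compounds shown here alone, is whether an amine or a carboxylic acid on this aromatic carbon would give a read-out like that of bromo.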